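Primary amine in place of hydroxypiperidine on a chromone chain

This account rests on a few compounds, and the source may have more. Where it says the series, first, only, none or still open, it means among the compounds named here.

Measured compounds:
compound 1, `CN(C)CCCCCCOc1ccc2oc(-c3ccccc3)cc(=O)c2c1`, 335 nM
compound 2, `CN(C)CCCCCCCOc1ccc2oc(-c3ccccc3)cc(=O)c2c1`, 188 nM
compound 3, `O=c1cc(-c2ccccc2)oc2ccc(OCCCCCCN3CCC(O)CC3)cc12`, 121 nM

Compound 3 gives the lowest number of the three in an assay on isolated protein (Cavia porcellus) with Sigma non-opioid intracellular receptor 1 (Homo sapiens) as the target, read by radioligand binding; on this read-out lower numbers stand for stronger inhibition and higher numbers for weaker inhibition. Its step from compound 2 is within the scatter, a 1.6-fold lower number from compound 2 to compound 3 (0.19 log units; within the scatter), while its step from compound 1 is beyond it, a 2.8-fold lower number from compound 1 to compound 3 (0.44 log units; beyond the scatter). Compound 4, `NCCCCCCOc1ccc2oc(-c3ccccc3)cc(=O)c2c1`, has not yet been measured. It differs from compound 3 in one place: amino in place of 4-hydroxypiperidin-1-yl on a saturated chain carbon, six bonds along the chain from an oxygen on an aromatic ring.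

For the measured compounds named here, the step that bears most directly on this change is the one from compound 1 to compound 3, where a dimethylamino became a 4-hydroxypiperidin-1-yl and the number fell modestly. Compound 4 moves in the opposite direction and further, to a bare amino, so the number is expected to rise rather than fall. The step from compound 1 to compound 2, a 1.8-fold lower number from compound 1 to compound 2 (0.25 log units; within the scatter), concerns the chain only and is within the scatter, so it adds little. The expected step is a 7.4-fold higher number from compound 3 to compound 4 (0.87 log units; beyond the scatter). Compound 4 is therefore estimated at 900 nM, with a range from 250 nM to 3500 nM.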

Compound 4, half-maximal inhibitory concentration: 3700 nM
Estimate against measurement, compound 4: 4.1-fold (0.61 log units) below; the whole stated range lies below it.
By their numbers in this assay, from the lowest: compounds 3, 2 and 1 (each within the scatter of the next, the first and the last beyond it); then compound 4.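

In this assay the amino group stands apart from all three larger groups at the chain end: from 4-hydroxypiperidin-1-yl (a 31-fold higher number from compound 3 to compound 4 (1.49 log units; beyond the scatter)), from (dimethylamino)methyl (a 20-fold higher number from compound 2 to compound 4 (1.29 log units; beyond the scatter)) and from dimethylamino (an 11-fold higher number from compound 1 to compound 4 (1.04 log units; beyond the scatter)). The earlier compounds shown here showed only small or modest steps among groups that all carry carbon on the nitrogen, whereas each step to the amino, with its single heavy atom, is large, so this position separates the bare amino sharply from those three groups. Nothing available here accounts for the size of these steps.

The compounds shown leave open whether one methyl on the nitrogen, as in methylamino, is enough to bring the number back down. They also leave open whether piperidin-1-yl without its hydroxyl would match compound 3, and whether an amino on a longer chain would behave the same way.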